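Compound 3: 3-iodophenyl in place of 4-iodophenyl

This account rests on a few compounds, and the source may have more. Where it says the series, first, only, none or still open, it means among the compounds named here.

Measured in an ADME assay on WI-38 cells (Homo sapiens) for cytotoxicity, read by MTT assay, with a stated time of 72 h; on this read-out higher numbers stand for weaker inhibition and lower numbers for stronger inhibition:
Compound 1 `CCNC(=O)CCc1cccc2c1B(O)OC2`: > 100000 nM, a limit of the assay
Compound 2 `O=C(CCc1cccc2c1B(O)OC2)Nc1ccc(I)cc1`: 49000 nM

Within the data shown here, compound 2 gives 49000 nM, the only actual number so far in this assay. Among the measured compounds shown here, the sole measured step, an at least 2.0-fold lower number from compound 1 to compound 2 (0.30 log units; that floor lies within the scatter), put 4-iodophenyl in place of ethyl on an amide-type nitrogen, and it rests on a limit. Compound 3 `O=C(CCc1cccc2c1B(O)OC2)Nc1cccc(I)c1` differs from compound 2 as follows: 3-iodophenyl in place of 4-iodophenyl on an amide-type nitrogen. For the measured compounds named here, no measured step tests this exchange, so no change beyond the scatter is expected in this assay. The expected step is a 1.1-fold lower number from compound 2 to compound 3 (0.04 log units; within the scatter). The estimate for compound 3 is 45000 nM, with an expected range of 20000 nM to 100000 nM.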

Compound 3, half-maximal inhibitory concentration: 71000 nM
Estimate against measurement, compound 3: 1.6-fold (0.20 log units) below; the measured number falls inside the stated range.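

In this assay, 3-iodophenyl in place of 4-iodophenyl on the amide-type nitrogen gives a 1.4-fold higher number from compound 2 to compound 3 (0.16 log units; within the scatter). Among these compounds, this is the first test of the exchange, and the two iodophenyl amides cannot be told apart in this read-out. The comparison with the ethyl amide yields only a floor, an at least 1.4-fold lower number from compound 1 to compound 3 (0.14 log units; that floor lies within the scatter), and it rests on a limit: the limit of > 100000 nM in this assay, at which 1 of the 3 values shown sits.

Still open, going by these compounds, is whether a plain phenyl, or an amine or a carboxylic acid in place of the iodine on that ring, would move the number beyond the scatter.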